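Lung half-life of a thienopyrimidinone series: compound 4

The compounds below may be only part of what the source reports. "The series", "measured", "known", "first", "only" and "open" are said of these compounds alone.

Compound 1 `Cc1csc2cc([C@H](C)Nc3ncnc(N)c3C#N)c(-c3cccc(CN4CCC(CN(C)Cc5ccccn5)CC4)c3)c(=O)n12`: 10.9 h
Compound 2 `Cc1csc2cc([C@H](C)Nc3ncnc(N)c3C#N)c(-c3cccc(CN(C)CCCCN(C)Cc4ccccc4)c3)c(=O)n12`: 17.6 h
Compound 3 `Cc1csc2cc([C@H](C)Nc3ncnc(N)c3C#N)c(Cc3cccc(CN(C)CC(C)C)c3)c(=O)n12`: 2.3 h

Of the compounds shown here, three sharing one core have so far been measured in an ADME assay on the whole organism (lung, Rattus norvegicus) for metabolic stability, read by LC-MS; on this read-out higher numbers stand for a longer-lived compound and lower numbers for a shorter-lived compound. Compound 1 gives 10.9 h, the second highest of the three numbers. Its nearest neighbour is compound 2, which gives 17.6 h, a gap that lies within the scatter of the method, so no order between compound 1 and compound 2 can be claimed. Compound 3 gives 2.3 h, a gap from compound 1 that lies beyond the scatter.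

The step now considered leads from compound 1 to compound 4 `Cc1csc2cc([C@H](C)Nc3ncnc(N)c3C#N)c(-c3cccc(CN4CCC(N(C)C)CC4)c3)c(=O)n12`. The structural change is dimethylamino in place of (methyl((pyridin-2-yl)methyl)amino)methyl on a saturated ring carbon.

For the measured compounds named here, no measured pair with a single change of this kind exists among the three compounds, so the direction of the step rests on the spread already seen. Compound 4 is expected to sit somewhat lower than compound 1, because compound 3 gives 2.3 h while compound 2 gives 17.6 h, and the step of a 1.6-fold lower number from compound 1 to compound 4 (0.19 log units; within the scatter) is estimated to fall near the edge of the scatter. The estimate for compound 4 is 7 h, with a range from 3 h to 16 h.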

Compound 4, half-life in the lung assay: 23.2 h
Beside the measured number, compound 4's estimate is 3.3-fold (0.52 log units) below it; the whole stated range lies below it.
By their numbers in the lung assay, from the lowest: compound 3; then compounds 1, 2 and 4 (each within the scatter of the next, the first and the last beyond it).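

For the compounds shown here, on the saturated ring carbon, three ring bonds from the ring nitrogen, this is the first single-change step in the lung assay (a 2.1-fold higher number from compound 1 to compound 4 (0.33 log units; beyond the scatter)), and it shows that the (methyl((pyridin-2-yl)methyl)amino)methyl group, with its six-membered aromatic ring, is not required for a long half-life. In a physicochemical assay for lipophilicity (on this read-out lower numbers stand for lower lipophilicity and higher numbers for higher lipophilicity), compound 1 gives 2 and compound 4 gives 0.5. The longer half-life of this pair therefore comes with a lower lipophilicity: the measured distribution coefficient of compound 1, 2, and of compound 4, 0.5, a number 1.50 log units lower (beyond the scatter).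

The compounds shown leave open whether the half-life follows the lipophilicity or the loss of the aromatic ring, which a single pair cannot settle. They also leave open how a methylamino group, a morpholine or a hydroxyl group on this ring carbon would read in the lung assay.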